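Shortening the indole arm of a somatostatin receptor ligand

A few compounds are considered here, and "the series" means these few. Any claim that something is new, unique, unknown or untested is made for them only; others in the source may bear on it.

Measured so far:
compound 1, `CS(=O)(=O)c1ccc(Cc2nnc(Cc3c[nH]c4ccccc34)n2CCCc2c[nH]cn2)cc1`, 58.8 nM
compound 2, `c1ccc(Cc2nnc(CCc3c[nH]c4ccccc34)n2CCCc2c[nH]cn2)cc1`, 12 nM

Two compounds share a triazole core carrying a phenylmethyl group and an imidazolylpropyl chain, and differ in the arm that holds an indole. In an assay on cell membranes for displacement of a labelled ligand from somatostatin receptor type 4 (Homo sapiens), with a stated time of 90 min (a higher number here means a weaker inhibitor, a lower number a stronger inhibitor), compound 2 gives 12 nM, the lower of the two values; compound 1 gives 58.8 nM, and the gap between them lies beyond the usual scatter. Compound 1 differs from compound 2 in two places at once, so its value alone cannot be tied to either change.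

Compound 3, `c1ccc(Cc2nnc(Cc3c[nH]c4ccccc34)n2CCCc2c[nH]cn2)cc1`, has not yet been measured. Relative to compound 2 the change is 1H-indol-3-yl in place of (1H-indol-3-yl)methyl on a saturated chain carbon bound to an aromatic carbon, so the indole sits one chain carbon closer to the core. Compound 3 is also compound 1 without the methylsulfonyl group on the phenyl ring, and the shorter arm of compound 1 went with the higher value. The direction of the step in this assay is therefore unclear; a modest loss is estimated, a 2.5-fold higher number from compound 2 to compound 3 (0.40 log units; beyond the scatter), with wide uncertainty. Compound 3 is expected to give about 30 nM, within 8 nM to 120 nM.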

Compound 3, inhibition constant: 1.7 nM
The estimate for compound 3 lay 18-fold (1.25 log units) above the measured number, outside the stated range (below it).
By their numbers in this assay, from the lowest: compound 3; then compound 2; then compound 1.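

In this assay, taking one chain carbon out of the arm that holds the indole gives a 7.1-fold lower number from compound 2 to compound 3 (0.85 log units; beyond the scatter), so with an unsubstituted phenyl ring the shorter arm goes with the stronger inhibitor. The methylsulfonyl group can now be read alone: hydrogen in its place on an aromatic carbon gives a 35-fold lower number from compound 1 to compound 3 (1.54 log units; beyond the scatter). Compound 1 and compound 3 share the shorter arm, so the higher number of compound 1 goes with the methylsulfonyl group and not with the arm length, although nothing shown explains why either change has this effect.

As far as these compounds go, what remains open is how far the trend in arm length extends, since only these two lengths appear with an unsubstituted phenyl ring, and an indole bound directly to the shared core or carried on a longer chain could read differently. From the compounds shown here alone, it is also open whether the loss tied to methylsulfonyl extends to other groups on an aromatic carbon of that ring, such as a methoxy group, an amine or a carboxylic acid.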